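A few compounds are considered here, and "the series" means these few. Any claim that something is new, unique, unknown or untested is made for them only; others in the source may bear on it.

Working notes on the trimethoxyphenyl amide series.

Three compounds have been run in a functional assay on Daoy cells (Homo sapiens) for cytotoxicity, read by MTT assay, with a stated time of 72 h (a higher number here means a weaker inhibitor, a lower number a stronger inhibitor), and all three sit at the assay limit. Compound 1 `COc1cc(N(C)C(=O)N(C)c2ccc([N+](=O)[O-])cc2)cc(OC)c1OC` is a urea; in this assay compound 1 gives >= 125000 nM, which is a limit and not a number. Compound 2 `COc1cc(N(C)C(=O)c2ccccc2)cc(OC)c1OC` is the unsubstituted benzamide; in this assay compound 2 gives >= 125000 nM, again a limit rather than a measured value. Compound 3 `COc1cc(NC(=O)c2cccc([N+](=O)[O-])c2)cc(OC)c1OC` carries a nitro group and an unmethylated amide; in this assay compound 3 gives >= 125000 nM, also a limit. For the measured compounds named here, no step between measured compounds can be computed, since the only thing the series shows so far is the limit of >= 125000 nM in this assay, at which 3 of the 3 values shown sit.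

Compound 4 `COc1cc(N(C)C(=O)c2cccc(F)c2)cc(OC)c1OC` is the next compound to be measured. It differs from compound 2 by fluoro in place of hydrogen on an aromatic carbon, that is, phenyl to 3-fluorophenyl. With every measured compound stuck at the limit, there is no basis to expect a change beyond the scatter; the step from compound 2 to compound 4 is expected to be a step that the limit leaves unreadable from compound 2 to compound 4, that is, none of note. For compound 4 the expected value in this assay is 150000 nM, within a range of 60000 nM to 400000 nM, and most likely reported only as a limit.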

Compound 4, half-maximal inhibitory concentration: >= 125000 nM
Compound 4 was reported as a limit; the forecaster's own chance of this, stated with the estimate: 85%; the middle value is on the limit's open side.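

No step can be read from compound 2 to compound 4 in this assay, as both are reported only as limits: the limit of >= 125000 nM in this assay, at which 4 of the 4 values shown sit.

The compounds shown leave open whether fluoro in place of hydrogen, or any other change within the series, alters potency in this assay.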